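The compounds below may be only part of what the source reports. "The series", "measured", "known", "first", "only" and "open" are said of these compounds alone.

Measured so far in a functional assay on A549 cells (Homo sapiens) for inhibition, read by MTT assay, with a stated time of 24 h; a lower number here means a stronger inhibitor, a higher number a weaker inhibitor:
Compound 1 `CCOC(=O)C1=Cc2ccccc2OC1(OCc1cn(CC(=O)Nc2ccccc2Br)nn1)C(F)(F)F` reaches only the assay limit, > 150000 nM.
Compound 2 `O=C(O)C1=Cc2ccccc2OC1(OCc1cc(-c2ccc(F)cc2F)no1)C(F)(F)F` likewise sits at the assay limit, > 150000 nM.
Compound 3 `CCOC(=O)C1=Cc2ccccc2OC1(OCc1cn(CC(=O)NC2CCCCC2)nn1)C(F)(F)F` gives 9900 nM.

Compound 2 therefore stands at the limit of > 150000 nM in this assay, at which 2 of the 3 values shown sit, a limit and not a number. For the measured compounds named here, the single measured step, an at least 15-fold lower number from compound 1 to compound 3 (1.18 log units; beyond the scatter), concerns an amide-type nitrogen on the triazole side chain and does not touch the place changed here. Compound 4 `O=C(O)C1=Cc2ccccc2OC1(OCc1cc(-c2cccc(C(F)(F)F)c2)no1)C(F)(F)F` differs from compound 2 by 3-(trifluoromethyl)phenyl in place of 2,4-difluorophenyl on an aromatic carbon. Going by the values given here, no measured step bears on this exchange, so no direction beyond the scatter can be expected from the data. The estimate for compound 4 is 150000 nM, between 30000 nM and 400000 nM, which means an expected step of a number no higher from compound 2 to compound 4 (the limit leaves the size open), most likely again only a limit.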

Compound 4, half-maximal inhibitory concentration: > 150000 nM
Compound 4 was reported as a limit (the forecaster's own chance of this, stated with the estimate: 70%); the middle value sits exactly at the limit.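

Compound 2 and compound 4 are both reported only as limits, so no step between them can be read: the limit of > 150000 nM in this assay, at which 3 of the 4 values shown sit.

The compounds shown leave open whether 3-(trifluoromethyl)phenyl in place of 2,4-difluorophenyl changes the read-out at all.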